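Swapping One Group on Two Related Cores

The source may report more compounds than this note shows. Statements on the series, on what has been measured and on what is new or still open speak of the compounds shown alone.

Compound 1 `CC1=C(C(=O)OC(C)(C)C)C(c2cccs2)NC(=S)N1` and compound 2 `CC1=C(C(=O)OCc2ccccc2)C(c2cccs2)NC(=S)N1` share a core and differ in a single place. In an assay on membranes from HEK293 cells for displacement of a labelled ligand from adenosine receptor A2b (Homo sapiens), read by scintillation counting, with a stated time of 30 min, tested at 1 uM (a higher number here means more inhibition at the concentration tested (going by the name of the read-out), a lower number less inhibition), compound 1 gives 26%, while compound 2 gives 45%. The change between them is benzyl in place of tert-butyl on an oxygen next to a carbonyl group and it made a step of a number 19 percentage points higher from compound 1 to compound 2 (beyond the scatter).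

Compound 3 `CC1=C(C(=O)OC(C)(C)C)C(c2ccoc2)NC(=O)N1C` is built on a different core; the difference between the two cores is not broken down here. In this assay compound 3 gives 16%, a number within the usual scatter of compound 1 and beyond the scatter below compound 2. Compound 4 `CC1=C(C(=O)OCc2ccccc2)C(c2ccoc2)NC(=O)N1C` has not yet been measured. It stands to compound 3 as compound 2 stands to compound 1, with the same change at the same place: benzyl in place of tert-butyl on an oxygen next to a carbonyl group. Among the compounds shown, this change occurs twice in all, and only one of the two instances has numbers on both sides.

Within the data shown here, the expected step is a number 17 percentage points higher from compound 3 to compound 4 (beyond the scatter), a size chosen to sit beside the earlier one, because a number 19 percentage points higher from compound 1 to compound 2 (beyond the scatter) is the only measured instance of this change and it was made on a different core, so the room for the new step is kept wide. For compound 4 the estimated result in this assay is 33%, expected to fall between 15% and 52%.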

Compound 4, a percentage reported as inhibition, at one concentration (the size of the read-out at that concentration, not a potency): 49%
Beside the measured number, compound 4's estimate is 16 percentage points below it; measured number inside the range.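

Putting benzyl in place of tert-butyl on an oxygen next to a carbonyl group again gives a higher reading in this assay, this time a number 33 percentage points higher from compound 3 to compound 4 (beyond the scatter). The change therefore acts in the same direction on both cores, and the two steps cannot be told apart in size: the same change on two cores in this assay, a number 19 percentage points higher (beyond the scatter) from compound 1 to compound 2 and a number 33 percentage points higher (beyond the scatter) from compound 3 to compound 4, 14 percentage points apart, within the scatter of two such steps. This is encouraging for carrying the change from one core to the other within this series, but it rests on just two pairs of compounds, does not predict the outcome on any further core, and gives no reason for the rise, while each reading comes from a single concentration and so is not a measure of potency.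

The compounds shown carry only tert-butyl or benzyl on that oxygen, which leaves open whether a longer chain such as n-butyl, or a chain ending in an amine, would read closer to tert-butyl or to benzyl. They also leave open what would happen if a carboxylic acid stood in place of the whole ester, and how the two cores themselves compare when nothing else differs.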